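The source may hold more compounds than are shown below. What is called first, only, known or untested is meant among the compounds shown, and "the series" means these compounds.

Compound 1 `CC1CN(c2ccccc2)NC(=O)N1O`: 13000 nM
Compound 2 `CC1CN(c2cccc(Cl)c2)NC(=O)N1O`: 3600 nM

Both compounds were tested in a functional assay on cells for inhibition of Polyunsaturated fatty acid 5-lipoxygenase (Homo sapiens); a higher number here means a weaker inhibitor, a lower number a stronger inhibitor. Going by the values given here, compound 2 gives the lower of the two numbers, and the only other measured compound, compound 1, gives 13000 nM. That gap is described by a 3.6-fold lower number from compound 1 to compound 2 (0.56 log units; beyond the scatter).

Compound 3 `Cc1cccc(N2CC(C)N(O)C(=O)N2)c1` differs from compound 2 by methyl in place of chloro on an aromatic carbon. Among the compounds with values here, the one measured step that bears on this change is a 3.6-fold lower number from compound 1 to compound 2 (0.56 log units; beyond the scatter), which shows that putting chloro at this aromatic carbon brought a modest gain over hydrogen. Methyl takes the same place as the chloro it replaces, so compound 3 is expected to land between the two measured compounds, with the step of a 1.5-fold higher number from compound 2 to compound 3 (0.18 log units; within the scatter) expected to be small and toward a higher number, possibly within the scatter. Compound 3 is therefore estimated at 5500 nM, with a range from 2000 nM to 15000 nM.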

Compound 3, half-maximal inhibitory concentration: 4800 nM
Estimate against measurement, compound 3: 1.1-fold (0.06 log units) above; the measured number falls inside the stated range.
By their numbers in this assay, from the lowest: compounds 2 and 3 (each within the scatter of the next); then compound 1.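

In this assay, methyl and chloro at this aromatic carbon cannot be told apart: the step is a 1.3-fold higher number from compound 2 to compound 3 (0.12 log units; within the scatter). Methyl in place of hydrogen also gives a modest gain, a 2.7-fold lower number from compound 1 to compound 3 (0.43 log units; beyond the scatter), so the improvement seen earlier is not unique to chloro but is shared by these two single-atom substituents on the shared core. Nothing measured here says what lies behind this likeness.

From the compounds shown here alone, it remains open whether a methoxy group, an amine, a carboxylic acid or a longer chain such as ethyl at this same aromatic carbon would keep, lose or extend the gain over hydrogen. Going by these compounds, it is also open whether chloro and methyl would again match each other on the other aromatic carbons of the ring.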